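Compound 2 to compound 3: a methoxy change on the chain

The source may report more compounds than this note shows. Statements on the series, on what has been measured and on what is new or still open speak of the compounds shown alone.

Measured so far:
compound 1 `Cc1noc(CC2OC(=O)c3ccccc32)n1`: > 40000 nM (a limit)
compound 2 `CCCOc1ccc(C(O)C2OC(=O)c3c(OC)cc(OC)cc32)cc1`: > 40000 nM (a limit)

In an ADME assay on RAW264.7 cells (Mus musculus) for cytotoxicity, read by MTT assay, with a stated time of 24 h, in the absence of a further agent (on this read-out lower numbers stand for stronger inhibition and higher numbers for weaker inhibition), compound 2 gives > 40000 nM, which is a limit and not a number. Compound 1 gives > 40000 nM, which is also a limit. The whole record so far is the limit of > 40000 nM in this assay, at which 2 of the 2 values shown sit. Among the measured compounds shown here, neither compound therefore has a numerical value, and no measured step connects them.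

Compound 3 `COCCOc1ccc(C(O)C2OC(=O)c3c(OC)cc(OC)cc32)cc1` is the next entry and differs from compound 2 in one place: methoxy in place of methyl on a saturated chain carbon, two bonds along the chain from an oxygen on an aromatic ring. Methoxy stands in place of methyl on a saturated chain carbon, two bonds along the chain from an oxygen on an aromatic ring, which turns propoxy into 2-methoxyethoxy.

For the measured compounds named here, with no measured step to draw on, the expectation rests only on compound 2 at > 40000 nM. No change beyond the usual scatter is expected in this assay, and no direction is favoured. The estimated step that the limit leaves unreadable from compound 2 to compound 3 is expected to stay within that scatter. Compound 3 is estimated at 50000 nM, with an expected range from 25000 nM to 100000 nM.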

Compound 3, half-maximal inhibitory concentration: > 40000 nM
Compound 3 gave a limit, no number; the forecaster's own chance of this, stated with the estimate: 85%; the middle value does not contradict the limit.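

Among the compounds shown here, no step from compound 2 to compound 3 can be read in this assay, as both results are limits and not numbers. The whole record stands at a single limit: the limit of > 40000 nM in this assay, at which 3 of the 3 values shown sit.

The compounds shown leave open what numerical value any of them would give in this assay, and whether methoxy in place of methyl changes that value at all.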